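Acetamido replaced by carbamoyl(methyl)amino on compound 2

The source may hold more compounds than are shown below. What is called first, only, known or untested is meant among the compounds shown, and "the series" means these compounds.

Compound 2 `CO[C@@H]1[C@H](NC(C)=O)C[C@H]2O[C@]1(C)n1c3ccccc3c3c4c(c5c6ccccc6n2c5c31)C(=O)NC4` gives 38 nM in an assay on isolated protein for inhibition of protein kinase C theta type (Homo sapiens), read by HTRF (a higher number here means a weaker inhibitor, a lower number a stronger inhibitor), the lowest of the two numbers in hand. Among the measured compounds shown here, compound 1 `CO[C@@H]1[C@H](NC(=O)C(=O)c2c[nH]c3ccccc23)C[C@H]2O[C@]1(C)n1c3ccccc3c3c4c(c5c6ccccc6n2c5c31)C(=O)NC4` gives 1790 nM in this assay, and the step of a 47-fold lower number from compound 1 to compound 2 (1.67 log units; beyond the scatter) is the only measured step in the set. Compound 3 `CO[C@@H]1[C@@H](O)[C@@H](O)[C@H]2O[C@]1(C)n1c3ccccc3c3c4c(c5c6ccccc6n2c5c31)C(=O)N[C@H]4OC` gives in this assay only a limit, > 2500 nM, which is the limit of > 2500 nM in this assay, at which 1 of the 3 values shown sits.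

Compound 4 `CO[C@@H]1[C@H](N(C)C(N)=O)C[C@H]2O[C@]1(C)n1c3ccccc3c3c4c(c5c6ccccc6n2c5c31)C(=O)NC4` differs from compound 2 by carbamoyl(methyl)amino in place of acetamido on a saturated ring carbon. For the measured compounds named here, the one measured step exchanged a large group for a methyl on a carbonyl carbon; the present change keeps a small group on a saturated ring carbon, so no measured step bears on it directly, and no change beyond the scatter is expected in this assay. Compound 4 is therefore estimated at 60 nM (range 20 nM to 200 nM), an expected step of a 1.6-fold higher number from compound 2 to compound 4 (0.20 log units; within the scatter).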

Compound 4, half-maximal inhibitory concentration: 400 nM
Compound 4: the middle estimate sits 6.7-fold (0.82 log units) below what was measured; the measured number lies above the stated range.
By their numbers in this assay, from the lowest: compound 2; then compound 4; then compound 1. At a limit, above all of these: compound 3.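

A small exchange on the saturated ring carbon is enough to shift the result: in this assay carbamoyl(methyl)amino in place of acetamido gives an 11-fold higher number from compound 2 to compound 4 (1.02 log units; beyond the scatter), although the hydrogen-bond donor and acceptor counts stay the same. The earlier step changed a large group on a carbonyl carbon, whereas this one shows that the series also responds to a change between small groups at this position. Nothing measured here accounts for the step.

Going by these compounds, whether the methyl on the nitrogen or the rearranged urea drives the step remains open. An unmethylated urea, a free amine or a methyl carbamate at this carbon would help separate these.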